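This account rests on a few compounds, and the source may have more. Where it says the series, first, only, none or still open, it means among the compounds named here.

Compound 2 `CC(C)(N)CC(=O)N[C@@H]1CCc2ccccc2N(Cc2ccc(-c3ccccc3S(=O)(=O)NC(C)(C)C)cc2)C1=O` stands highest of the two numbers in a functional assay (Pituitary gland cell) with Rattus norvegicus as the target; a higher number here means that more compound is needed for the effect, a lower number that less compound is needed: compound 2 gives 4 uM, while compound 1 `Cn1nnnc1-c1ccccc1-c1ccc(CN2C(=O)[C@H](NC(=O)CC(C)(C)N)CCc3ccccc32)cc1` gives 0.5 uM. Within the data shown here, the one measured step, an 8.0-fold higher number from compound 1 to compound 2 (0.90 log units; beyond the scatter), changed the same aromatic carbon. Compound 3 `CC(C)(N)CC(=O)N[C@@H]1CCc2ccccc2N(Cc2ccc(-c3ccccc3C(N)=O)cc2)C1=O` differs from compound 2 by carbamoyl in place of (tert-butyl)sulfamoyl on an aromatic carbon. That step showed the place matters, but gives no direction for the carbamoyl, so no step beyond the scatter is expected, a 1.3-fold higher number from compound 2 to compound 3 (0.10 log units; within the scatter). Compound 3 is therefore estimated at 5 uM, with a range from 1.5 uM to 20 uM.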

Compound 3, concentration for half-maximal effect: 0.08 uM
Compound 3: middle estimate off by 63-fold (1.80 log units), on the high side, and the stated range ends above it.
By their numbers in this assay, from the lowest: compound 3; then compound 1; then compound 2.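

At this aromatic carbon the number can fall as well as rise: carbamoyl, with 3 heavy atoms against 8 in (tert-butyl)sulfamoyl, gives a 50-fold lower number from compound 2 to compound 3 (1.70 log units; beyond the scatter). It also outdoes 1-methyl-1H-tetrazol-5-yl, with a 6.3-fold lower number from compound 1 to compound 3 (0.80 log units; beyond the scatter), leaving compound 3 with the lowest number of the three. No evidence here accounts for these steps. The compounds shown leave open whether a carboxylic acid or an amine on this carbon would keep the number as low. They also do not separate the size of the group from its other features.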